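This account rests on a few compounds, and the source may have more. Where it says the series, first, only, none or still open, it means among the compounds named here.

Compound 3, `COc1ccc(Nc2cc3[nH]c(-c4cccc(C(F)(F)F)c4)nc3cn2)nc1`, in a physicochemical assay for solubility, using the shake flask method, measured as kinetic solubility, with a stated time of 20 h, at pH 2 (a higher number here means a more soluble compound, a lower number a less soluble compound), reaches only a limit, < 5000 nM. Compound 2, `COc1ccnc(Nc2cc3[nH]c(-c4cccc(C(F)(F)F)c4)nc3cn2)c1`, likewise sits at a limit in this assay, < 5000 nM. For the measured compounds named here, the one compound with a read number is compound 1, `FC(F)(F)Oc1ccc(-c2nc3cnc(Nc4ccccn4)cc3[nH]2)cc1`, which in this assay gives 26000 nM. Going by the values given here, the single measured step, a step that the two limits leave unreadable from compound 2 to compound 3, cannot be read in size or direction, since both ends rest on (the limit of < 5000 nM in this assay, at which 2 of the 3 values shown sit).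

Compound 4, `FC(F)(F)c1cccc(-c2nc3cnc(Nc4cccnn4)cc3[nH]2)c1`, differs from compound 3 in one place: pyridazin-3-yl in place of 5-methoxypyridin-2-yl on a nitrogen on an aromatic ring. Among the compounds with values here, no measured step covers this exchange, and the only step gives no readable size, so there is no guide for the direction or the size of the change beyond the expectation that compound 4 stays near the region where compound 3 lies. The estimated step is therefore a number no lower from compound 3 to compound 4 (the limit leaves the size open), an expectation rather than a reading. On that basis compound 4 is estimated at 5000 nM in this assay, with a range from 1500 nM to 20000 nM, and a fair chance that the assay again returns only a limit.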

Compound 4, solubility: 161000 nM
For compound 4 the middle estimate is 32-fold (1.51 log units) below the measured one, and the stated range ends below it.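

At this position, on a nitrogen on an aromatic ring, the exchange gives the series its first readable step in this assay: pyridazin-3-yl for 5-methoxypyridin-2-yl gives an at least 32-fold higher number from compound 3 to compound 4 (1.50 log units; beyond the scatter), and pyridazin-3-yl for 4-methoxypyridin-2-yl gives an at least 32-fold higher number from compound 2 to compound 4 (1.50 log units; beyond the scatter). So the group at this position can move the read-out well beyond the scatter, whereas the step between the two methoxypyridinyl compounds, compound 2 and compound 3, still cannot be read. Both new steps start from a limit of the assay, so each gives a minimum size and not an exact one: the limit of < 5000 nM in this assay, at which 2 of the 4 values shown sit.

The exchange adds a second ring hetero atom and removes the methoxy together, so the compounds shown do not tell which of the two changes carries the step. A pyridazin-3-yl bearing a methoxy or an amine would separate these two changes and show how far the ring itself tolerates substitution.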